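Longer Ester Chains on a Shared Core Against Green Algae

A few compounds are considered here, and "the series" means these few. Any claim that something is new, unique, unknown or untested is made for them only; others in the source may bear on it.

Compound 1 `COC(=O)c1cc(N2C(=O)C3=C(CCCC3)C2=O)c(F)cc1Cl` and compound 2 `CCCCOC(=O)c1cc(N2C(=O)C3=C(CCCC3)C2=O)c(F)cc1Cl` share one core and differ only in the ester chain. In a functional assay on the whole organism with Scenedesmus acutus as the target, with a stated time of 20 h (a higher number here means a weaker inhibitor, a lower number a stronger inhibitor), compound 1 gives 170 nM, and compound 2 gives 141 nM. The change between them, (propyl in place of hydrogen on a saturated chain carbon bound to an oxygen next to a carbonyl group), made a 1.2-fold lower number from compound 1 to compound 2 (0.08 log units; within the scatter). Compound 3 `CCCCCOC(=O)c1cc(N2C(=O)C3=C(CCCC3)C2=O)ccc1Cl` carries a different core; the difference between the two cores is not broken down here. In this assay compound 3 gives 5370 nM. Compound 4 `CCCCCCCCOC(=O)c1cc(N2C(=O)C3=C(CCCC3)C2=O)ccc1Cl` is still to be measured. It arises from compound 3 by propyl in place of hydrogen on a saturated chain carbon, five bonds along the chain from an oxygen next to a carbonyl group, the same kind of change as before, though here the place is five bonds along the chain from an oxygen next to a carbonyl group rather than bound to that oxygen. The step is expected to be small, a 1.2-fold higher number from compound 3 to compound 4 (0.08 log units; within the scatter), because a 1.2-fold lower number from compound 1 to compound 2 (0.08 log units; within the scatter) stayed within the scatter. Compound 4 is therefore estimated at 6500 nM, with a likely range from 2500 nM to 20000 nM.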

Compound 4, half-maximal inhibitory concentration: > 100000 nM
Compound 4: a limit, no number; the forecaster's own chance of this, stated with the estimate: 10%; at least 15-fold (1.18 log units) between middle value and limit.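

In this assay compound 4 gives > 100000 nM, which is a limit of the assay and not a number. Adding propyl gave an at least 18-fold higher number from compound 3 to compound 4 (1.27 log units; beyond the scatter), so a step that stayed small on the core of compound 1 did not stay small on the core of compound 3, and the change did not carry over: the same change on two cores in this assay, a 1.2-fold lower number (0.08 log units; within the scatter) from compound 1 to compound 2 and an at least 18-fold higher number (1.27 log units; beyond the scatter) from compound 3 to compound 4, at least 22-fold (1.35 log units) apart, beyond the scatter of two such steps With only one pair on each core, this does not show whether the core or the place of the change is behind the gap, since propyl sits on the carbon bound to the oxygen in one pair and five bonds along the chain in the other.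

Still open, from the compounds shown here alone, is how a hexyl ester on the core of compound 3 would behave, and what an octyl ester would do on the core of compound 1.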